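Moving from a difluorobenzyl to a chlorobenzyl on the shared core

The source may hold more compounds than are shown below. What is called first, only, known or untested is meant among the compounds shown, and "the series" means these compounds.

Three compounds share one core and differ only in the group carried on the saturated chain carbon bound to an aromatic nitrogen. Compound 1 `CCCn1c(=O)c2nc(-c3cnn(Cc4cc(C(F)(F)F)ccc4Cl)c3)[nH]c2n(CCC)c1=O` carries a 2-chloro-5-trifluoromethylbenzyl there; in an assay on CHO cells for displacement of a labelled ligand from adenosine receptor A1 (Homo sapiens) (on this read-out higher numbers stand for weaker inhibition and lower numbers for stronger inhibition), compound 1 gives 1200 nM. Compound 2 `CCCn1c(=O)c2nc(-c3cnn(Cc4c(F)cccc4F)c3)[nH]c2n(CCC)c1=O` carries a 2,6-difluorobenzyl, but in this assay compound 2 is recorded as "not determined" (no result reported), so its standing cannot be given. Compound 3 `CCCn1c(=O)c2nc(-c3cnn(Cc4cccc(Cl)c4)c3)[nH]c2n(CCC)c1=O` is reached from compound 2 by one change: 3-chlorophenyl in place of 2,6-difluorophenyl on a saturated chain carbon bound to an aromatic nitrogen. For the measured compounds named here, no measured pair shows this particular exchange, so the size of the step cannot be read from the data; with only compound 1 as a reference for a halogenated benzyl on this core, no direction beyond the usual scatter can be claimed. Compound 3 is therefore expected to land near 1000 nM in this assay, within a range of 250 nM to 4000 nM.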

Compound 3, inhibition constant: 31 nM
Beside the measured number, compound 3's estimate is 32-fold (1.51 log units) above it, and the stated range ends above it.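

In this assay, the group on a saturated chain carbon bound to an aromatic nitrogen proves able to shift the read-out strongly: 3-chlorophenyl in place of 2-chloro-5-(trifluoromethyl)phenyl gives a 39-fold lower number from compound 1 to compound 3 (1.59 log units; beyond the scatter), a large step beyond the scatter. Compound 1 alone could not show this sensitivity, and the step from compound 2 to compound 3 still cannot be read, as compound 2 has no reported result. No other measurement shown bears on the size of this step.

The compounds shown do not separate the part played by the trifluoromethyl group from that of the chlorine arrangement in this step. From the compounds shown here alone, whether a plain benzyl, or a phenyl carrying a methoxy group or an amine, would keep the lower number also remains open.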